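Fluoro analog in the benzyl-substituted series

The compounds below may be only part of what the source reports. "The series", "measured", "known", "first", "only" and "open" are said of these compounds alone.

Measured so far:
compound 1, `Nc1ncnc2c1ncn2Cc1ccc(F)cc1`, 0%
compound 2, `c1ccc(Cc2[nH]cnc3ncnc2-3)cc1`, 0%

Two compounds have been run in an assay on isolated protein for inhibition of RAC-alpha serine/threonine-protein kinase (Homo sapiens), tested at 30 uM; a lower number here means less inhibition, a higher number more inhibition at the concentration tested (going by the name of the read-out). Compound 1 gives 0% and compound 2 gives 0%; compound 2 stands level with compound 1 at the digits printed, the two values lying within the scatter of each other. Going by the values given here, no step between the two is computed, since they differ in more than one place: compound 1 carries a fluorine on its benzyl ring and a different core, while compound 2 carries the unsubstituted benzyl group on its own core.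

Compound 3, `Fc1ccc(Cc2[nH]cnc3ncnc2-3)cc1`, is the next candidate for this assay. It differs from compound 2 by fluoro in place of hydrogen on an aromatic carbon. The same fluorophenyl group is present in compound 1, which shows no inhibition in this assay, and compound 2 shows none either; nothing in the two values available suggests the change would move the read-out.

Compound 3 is therefore expected to give 0%, in the range -10% to 10%. The expected step of no change at the digits printed from compound 2 to compound 3 (within the scatter) is none beyond the scatter.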

Compound 3, a percentage reported as inhibition, at one concentration (the size of the read-out at that concentration, not a potency): 3%
Compound 3: middle estimate off by 3 percentage points, on the low side, and the stated range covers the measured number.
By their numbers in this assay, from the lowest: compounds 1, 2 and 3 (each within the scatter of the next).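

In this assay, fluoro in place of hydrogen on an aromatic carbon, para to a large group, gives a number 3 percentage points higher from compound 2 to compound 3 (within the scatter). Going by these compounds alone, this is the first comparison that isolates a single change, since compound 1 and compound 2 differ in more than one place and could not separate the fluoro group from the core. On the core shared by compound 2 and compound 3, the read-out at the single concentration tested therefore does not distinguish fluoro from hydrogen at this position, and nothing available bears on the reason for this result.

Still open, as far as these compounds go, is whether a different group at the same place, such as an amine, a carboxylic acid or a methoxy group, would give a read-out beyond the scatter of compound 2. Also open, from the compounds shown here alone, is whether replacing the benzyl group with a longer chain, or changing the core itself, would bring any compound in this set clearly above the values seen so far in this assay.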